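Aryl piperazine variation on the ring nitrogen

This account rests on a few compounds, and the source may have more. Where it says the series, first, only, none or still open, it means among the compounds named here.

Measured compounds:
compound 1 `CCCc1nc(-c2ccccc2)c(CNCCN2CCN(c3cccc(C(F)(F)F)c3)CC2)o1` — 56.3%
compound 2 `CCCc1nc(-c2ccccc2)c(CNCCN2CCN(c3ccccc3F)CC2)o1` — 46.5%
compound 3 `CCCc1nc(-c2ccccc2)c(CNCCN2CCN(c3ccccc3Cl)CC2)o1` — 60.1%

In an assay on HEK293 cells for inhibition of Voltage-dependent T-type calcium channel subunit alpha-1G (Homo sapiens), read by fluorescence, tested at 10 uM (a lower number here means less inhibition, a higher number more inhibition at the concentration tested (going by the name of the read-out)), compound 3 gives 60.1%, the top number of the three, though compound 1 is within the scatter of it (a number 3.8 percentage points higher from compound 1 to compound 3 (within the scatter)) and only compound 2 falls clearly beyond (a number 13.6 percentage points higher from compound 2 to compound 3 (beyond the scatter)). Compound 4 `CCCc1nc(-c2ccccc2)c(CNCCN2CCN(c3ccc(C)cc3)CC2)o1` differs from compound 3 in one place: 4-methylphenyl in place of 2-chlorophenyl on an amine nitrogen in a ring. Going by the values given here, no measured step exchanges a chlorophenyl for a methylphenyl. The aryl exchanges seen so far were a number 9.8 percentage points lower from compound 1 to compound 2 (within the scatter) and a number 3.8 percentage points higher from compound 1 to compound 3 (within the scatter), and the halogen exchange a number 13.6 percentage points higher from compound 2 to compound 3 (beyond the scatter); all are small. A step of a number 10.1 percentage points lower from compound 3 to compound 4 (beyond the scatter) is therefore expected, probably none beyond the scatter, with a slight downward lean. Compound 4 is estimated at 50% in this assay, expected between 35% and 65%.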

Compound 4, a percentage reported as inhibition, at one concentration (the size of the read-out at that concentration, not a potency): 48.1%
Estimate against measurement, compound 4: 1.9 percentage points above; low and high end bracket the measured number.
By their numbers in this assay, from the lowest: compounds 2, 4, 1 and 3 (each within the scatter of the next, the first and the last beyond it).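

In this assay, the 4-methylphenyl group, the first aryl here with no halogen atom, gives a number 12 percentage points lower from compound 3 to compound 4 (beyond the scatter), while a number 1.6 percentage points higher from compound 2 to compound 4 (within the scatter) and a number 8.2 percentage points lower from compound 1 to compound 4 (within the scatter). A halogen on the aryl is thus not needed to reach the level of 2-fluorophenyl or 3-(trifluoromethyl)phenyl, and only 2-chlorophenyl stands clearly apart from 4-methylphenyl. No measurement here explains these steps.

The names 2-chlorophenyl and 4-methylphenyl differ in both the group and its place, so this step does not separate the two. On these data alone, how a methoxy group or an amide on the aryl would read remains open.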